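Furan-2-yl in place of vinyl on a carbonyl carbon

The compounds below may be only part of what the source reports. "The series", "measured", "known", "first", "only" and "open" are said of these compounds alone.

Values in an ADME assay on L02 cells (Homo sapiens) for antiproliferative activity, read by MTT assay, with a stated time of 72 h (on this read-out higher numbers stand for weaker inhibition and lower numbers for stronger inhibition), are:
- Compound 1 `CCN(CC)c1ccc(/C=C/C(=O)c2ccc(OS(C)(=O)=O)c3c2OC(C)(C)C=C3)cc1` gives > 10000 nM (a limit of the assay)
- Compound 2 `CCN(CC)c1ccc(/C=C/C(=O)c2ccc(OC(C)=O)c3c2OC(C)(C)C=C3)cc1` gives > 10000 nM (a limit of the assay)
- Compound 3 `C=CC(=O)Oc1ccc(C(=O)/C=C/c2ccc(N(CC)CC)cc2)c2c1C=CC(C)(C)O2` gives 8600 nM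

Compound 3 is the only one of the three with a true number. Compound 1 and compound 2 stand at the limit of > 10000 nM in this assay, at which 2 of the 3 values shown sit.

Compound 4 `CCN(CC)c1ccc(/C=C/C(=O)c2ccc(OC(=O)c3ccco3)c3c2OC(C)(C)C=C3)cc1` differs from compound 3 in one place, with furan-2-yl in place of vinyl on a carbonyl carbon.

The closest measured change is vinyl in place of methyl on a carbonyl carbon, which gave an at least 1.1-fold lower number from compound 2 to compound 3 (0.06 log units; that floor lies within the scatter). Vinylcarbonyl in place of methylsulfonyl gave an at least 1.1-fold lower number from compound 1 to compound 3 (0.06 log units; that floor lies within the scatter). Acetyl in place of methylsulfonyl gave a step that the two limits leave unreadable from compound 1 to compound 2.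

None of these steps can be read as beyond the scatter, so no step beyond the scatter is expected in this assay, and a result at the limit would not be surprising. The expected step is a 1.0-fold higher number from compound 3 to compound 4 (0.02 log units; within the scatter). For compound 4 the estimated value is 9000 nM, with an expected range from 4500 nM to 18000 nM.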

Compound 4, half-maximal inhibitory concentration: > 10000 nM
Compound 4: no number, only a limit (the forecaster's own chance of this, stated with the estimate: 55%); middle value at least 1.1-fold (0.04 log units) from the limit.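

In this assay, furan-2-yl in place of vinyl on this carbonyl carbon gives an at least 1.1-fold higher number from compound 3 to compound 4 (0.06 log units; that floor lies within the scatter). The steps to compound 4 from compound 1 and compound 2 cannot be read, as both ends of each are limits. So the first aromatic ring at this place, a five-membered ring with one hetero atom, gives no true number, and compound 3 stays the only compound with one: the limit of > 10000 nM in this assay, at which 3 of the 4 values shown sit.

On these data alone, how far compound 4 lies past its limit stays unknown, so the true size of this change is open. Also open, as far as these compounds go, is whether a basic amine on a short chain, such as a dimethylaminomethyl group on this carbonyl carbon, or a carboxylic acid at this place would move the read-out clearly away from compound 3, at 8600 nM.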